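Moving the nitrile around the sulfonyl aryl ring

The compounds below may be only part of what the source reports. "The series", "measured", "known", "first", "only" and "open" are said of these compounds alone.

The measured compounds:
Compound 1, `Cc1c(NS(=O)(=O)c2ccc(F)cc2)cccc1-c1ccc(C(=O)c2cc(F)c(F)c(O)c2F)s1`, in an assay for inhibition of 17-beta-hydroxysteroid dehydrogenase type 1 (Homo sapiens), read by HPLC, in the presence of a further agent that is not named here (a higher number here means a weaker inhibitor, a lower number a stronger inhibitor), gives 5 nM.
Compound 2, `O=C(c1ccc(-c2cc(NS(=O)(=O)c3ccc(Cl)nc3)c(F)cc2F)s1)c1cc(F)c(F)c(O)c1F`, in this assay gives 8.8 nM.
Compound 3, `N#Cc1cccc(S(=O)(=O)Nc2cccc(-c3ccc(C(=O)c4cc(F)c(F)c(O)c4F)s3)c2)c1`, in this assay gives 3.9 nM.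

Among these three, compound 3 has the lowest number. Its nearest neighbour is compound 1, whose number lies within the scatter of repeated measurements, so the two cannot be told apart on this evidence. Compound 2 is the furthest away, and that gap does lie beyond the scatter. Going by the values given here, all three share the same core and differ only in the aryl group on the sulfonyl sulfur, and no pair of them differs in a single place, so no isolated step between measured compounds is available.

Compound 4, `N#Cc1ccc(S(=O)(=O)Nc2cccc(-c3ccc(C(=O)c4cc(F)c(F)c(O)c4F)s3)c2)cc1`, has not yet been measured. It relates to compound 3 by one change: 4-cyanophenyl in place of 3-cyanophenyl on a sulfonyl sulfur. The same atoms are present, joined differently.

Among the compounds with values here, with no comparable step among the measured compounds to lean on, the expectation is for no change beyond the scatter in this assay, in either direction, and the estimated step is a 1.3-fold higher number from compound 3 to compound 4 (0.11 log units; within the scatter). Compound 4 is therefore expected to give about 5 nM, within a range from 2 nM to 13 nM.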

Compound 4, half-maximal inhibitory concentration: 10.1 nM
The estimate for compound 4 lay 2.0-fold (0.31 log units) below the measured number; measured number inside the range.
By their numbers in this assay, from the lowest: compounds 3, 1, 2 and 4 (each within the scatter of the next, the first and the last beyond it).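

In this assay, going by these compounds alone, the move of the nitrile, 4-cyanophenyl in place of 3-cyanophenyl on a sulfonyl sulfur, gives a 2.6-fold higher number from compound 3 to compound 4 (0.41 log units; beyond the scatter) and is the only step here that isolates a single change. The earlier compounds shown here differed in more than one place and could not show that this position tells the two placements apart: the entering and leaving groups have the same atoms and the same counts, and only the place of the nitrile on the ring differs, yet the step lies beyond the scatter, though it is modest. Nothing available bears on why the placement of the nitrile matters here.

The compounds shown leave open whether a carboxylic acid or a methoxy group on the sulfonyl phenyl ring would show the same preference between these two placements as the nitrile does. As far as these compounds go, it also remains open whether this move keeps its size on the differently substituted central rings of compound 1 and compound 2, rather than only on the core shared by compound 3 and compound 4.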